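Extending a Saturated Chain on a Shared Core

The source may hold more compounds than are shown below. What is called first, only, known or untested is meant among the compounds shown, and "the series" means these compounds.

Of the compounds shown here, two with the same core have been measured so far. Compound 1 `CCCCCOC(=O)CCC(=O)N1CCN(CCCOc2cc3c(Nc4ccc(F)c(Cl)c4)ncnc3cc2OC)CC1` carries a pentyl chain on an oxygen next to a carbonyl group, and in a functional assay on A549 cells (Homo sapiens) for cytotoxicity, read by MTT assay, with a stated time of 24 h, tested at 10 uM (a lower number here means a stronger effect, a higher number a weaker effect of the compound at the concentration tested), compound 1 gives 87.1%. Compound 2 `CCCCCCCCCCCCOC(=O)CCC(=O)N1CCN(CCCOc2cc3c(Nc4ccc(F)c(Cl)c4)ncnc3cc2OC)CC1` has the same core, and in this assay compound 2 gives 95.5%. Among the compounds with values here, the one step between them, a number 8.4 percentage points higher from compound 1 to compound 2 (within the scatter), is within the scatter, so the two numbers cannot be told apart. Compound 2 stands highest of the two numbers, with compound 1 nearest, but that difference carries no weight.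

Compound 3 `CCCCCCCCCCCCCCCCCCCCOC(=O)CCC(=O)N1CCN(CCCOc2cc3c(Nc4ccc(F)c(Cl)c4)ncnc3cc2OC)CC1` differs from compound 2 by octyl in place of hydrogen on a saturated chain carbon, ten or more bonds along the chain from an oxygen next to a carbonyl group. Within the data shown here, the only step that bears on this change is the earlier chain extension, a number 8.4 percentage points higher from compound 1 to compound 2 (within the scatter), which was within the scatter. On that basis no step beyond the scatter is expected in this assay from compound 2 to compound 3, and the estimated step is a number 0.5 percentage points higher from compound 2 to compound 3 (within the scatter). For compound 3 the expected value in this assay is 96%, with a range from 85% to 104%.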

Compound 3, a percentage reported as activity, at one concentration (the size of the read-out at that concentration, not a potency): 94%
The estimate for compound 3 lay 2 percentage points above the measured number; the measured number falls inside the stated range.
By their numbers in this assay, from the lowest: compounds 1, 3 and 2 (each within the scatter of the next).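

The result extends what the earlier step could show: a second, larger addition to the chain, octyl in place of hydrogen on a saturated chain carbon, ten or more bonds along the chain from an oxygen next to a carbonyl group, also leaves this assay without a readable change (a number 1.5 percentage points lower from compound 2 to compound 3 (within the scatter)). Together with the earlier heptyl addition (a number 8.4 percentage points higher from compound 1 to compound 2 (within the scatter)), this means that neither of the two chain extensions shown separates its pair of compounds, so across compound 1, compound 2 and compound 3 this assay gives no sign that the number follows the length of this saturated chain. No measured information is available that could explain this flat result.

The compounds shown leave open whether anything other than a plain saturated chain at this position would produce a step beyond the scatter, for example a chain ending in an amine or a carboxylic acid, or a phenyl ring in its place. They also leave open whether a much shorter group, such as methyl, would behave like the longer chains in this single-concentration read-out, which is not a potency.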